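A few compounds are considered here, and "the series" means these few. Any claim that something is new, unique, unknown or untested is made for them only; others in the source may bear on it.

Compound 1 (`CCOC(=O)c1oc2ccc(NS(=O)(=O)c3ccc(F)cc3)cc2c1C`) in a functional assay on HCT-116 cells (Homo sapiens) for inhibition, read by MTT assay, with a stated time of 72 h (a lower number here means a stronger inhibitor, a higher number a weaker inhibitor), gives 10500 nM.
Compound 2 (`CCOC(=O)c1oc2ccc(N(Cc3ccccc3)S(=O)(=O)c3ccc([N+](=O)[O-])cc3)cc2c1C`) in this assay gives only a limit, > 40000 nM.

Among the measured compounds shown here, compound 2 thus stands at the limit of > 40000 nM in this assay, at which 1 of the 2 values shown sits, so no number is known for it and no measured step starts from it. Compound 3 (`CCOC(=O)c1oc2ccc(N(Cc3ccccc3)S(=O)(=O)c3ccc(F)cc3)cc2c1C`) differs from compound 2 by fluoro in place of nitro on an aromatic carbon. For the measured compounds named here, no pair of measured compounds shows this change, so the size of the step rests on expectation alone; a move toward a stronger inhibitor, expected to read an at least 1.3-fold lower number from compound 2 to compound 3 (0.12 log units; that floor lies within the scatter) in this assay, is the working assumption, with a fair chance that only a limit is returned again. Compound 3 is estimated at 30000 nM, between 8000 nM and 100000 nM.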

Compound 3, half-maximal inhibitory concentration: 5820 nM
The estimate for compound 3 lay 5.2-fold (0.71 log units) above the measured number; the measured number lies below the stated range.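

With benzyl kept on the sulfonamide nitrogen, the change from 4-nitrophenyl to 4-fluorophenyl gives, in this assay, an at least 6.8-fold lower number from compound 2 to compound 3 (0.83 log units; beyond the scatter), so this position responds to the change. Compound 2 has a limit rather than a number, so that step is only a bound: the limit of > 40000 nM in this assay, at which 1 of the 3 values shown sits.

Benzyl in place of hydrogen on the sulfonamide nitrogen, with 4-fluorophenyl kept, gives a 1.8-fold lower number from compound 1 to compound 3 (0.26 log units; within the scatter), so benzyl is tolerated there in this assay.

The compounds shown leave open how an amine or a carboxylic acid in place of fluoro would read. Also open, going by these compounds, is how a longer chain in place of benzyl would read.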